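This account rests on a few compounds, and the source may have more. Where it says the series, first, only, none or still open, it means among the compounds named here.

Measured compounds:
compound 1 `CC#C[C@@H](Cc1nnn[nH]1)c1ccc(OCc2ccc3scc(-c4cccnc4C)c3c2)cc1`, 88 nM in a functional assay on cells for agonist activity at Free fatty acid receptor 1 (Homo sapiens), read by FLIPR and calcium flux; on this read-out lower numbers stand for an effect already at smaller amounts and higher numbers for an effect only at larger amounts of compound
compound 2 `CC#C[C@@H](Cc1nnn[nH]1)c1ccc(OCc2ccc3sc(F)c(-c4ccccc4C)c3c2)cc1`, 15 nM in this assay

Of these two numbers compound 1 gives the higher one, and the gap between compound 1 and compound 2 lies beyond the usual scatter of the measurement. Compound 3 `CC#C[C@@H](Cc1nnn[nH]1)c1ccc(OCc2ccc3scc(-c4cc(OCCOC)ccc4C)c3c2)cc1` is not yet measured; it differs from compound 1 in one place: 5-(2-methoxyethoxy)-2-methylphenyl in place of 2-methylpyridin-3-yl on an aromatic carbon. Among the measured compounds shown here, no measured pair shows this particular change on this core, so its effect is unknown. A step of moderate size toward a lower number is expected, since the larger group keeps the methyl and adds a chain. For compound 3 a value of 40 nM is estimated, within 12 nM to 130 nM, a step of a 2.2-fold lower number from compound 1 to compound 3 (0.34 log units; beyond the scatter).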

Compound 3, half-maximal effective concentration: 85 nM
Beside the measured number, compound 3's estimate is 2.1-fold (0.33 log units) below it, and the stated range covers the measured number.
By their numbers in this assay, from the lowest: compound 2; then compounds 3 and 1 (each within the scatter of the next).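

Putting 5-(2-methoxyethoxy)-2-methylphenyl in place of 2-methylpyridin-3-yl gives a 1.0-fold lower number from compound 1 to compound 3 (0.02 log units; within the scatter) in this assay. This position on the five-membered aromatic ring therefore accepts a larger group, with an added chain and a carbon-only ring, without a readable change in the number. Nothing measured here explains why the number holds.

As far as these compounds go, the ring nitrogen and the chain change together in this step, so their separate effects stay open. Also open, from the compounds shown here alone, is what an amine or a carboxylic acid would do in place of the 2-methoxyethoxy chain.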